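Tryptamine series: amine substituent and agonist potency

The source may hold more compounds than are shown below. What is called first, only, known or untested is meant among the compounds shown, and "the series" means these compounds.

Compound 1 `O=S(=O)(NCC1CCN(CCCc2c[nH]c3ccc(-n4cnnc4)cc23)CC1)c1ccccc1` gives 12 nM in an assay on CHO cells for agonist activity at 5-hydroxytryptamine receptor 1D (Homo sapiens), read by GTPgammaS binding (on this read-out higher numbers stand for an effect only at larger amounts of compound and lower numbers for an effect already at smaller amounts), and compound 2 `c1ccc(CNCC2CCN(CCCc3c[nH]c4ccc(-n5cnnc5)cc34)CC2)cc1` gives 5.6 nM. Among the compounds with values here, the single measured step, a 2.1-fold lower number from compound 1 to compound 2 (0.33 log units; beyond the scatter), is a modest gain, so compound 2 stands at the lower of the two numbers, with compound 1 beyond the scatter above it. Compound 3 `CC(=O)Nc1ccc([C@H](C)NCC2CCN(CCCc3c[nH]c4ccc(-n5cnnc5)cc34)CC2)cc1` differs from compound 2 by 1-(4-acetamidophenyl)ethyl in place of benzyl on an amine nitrogen. Within the data shown here, no measured step bears directly on this change; the one recorded step concerns phenylsulfonyl against benzyl, not a substituted benzyl. For compound 3 the expected step is a 1.1-fold higher number from compound 2 to compound 3 (0.03 log units; within the scatter), within the scatter. The estimate for compound 3 is 6 nM, range 2 nM to 18 nM.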

Compound 3, half-maximal effective concentration: 3 nM
Beside the measured number, compound 3's estimate is 2.0-fold (0.30 log units) above it; low and high end bracket the measured number.
By their numbers in this assay, from the lowest: compounds 3 and 2 (each within the scatter of the next); then compound 1.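

On an amine nitrogen, 1-(4-acetamidophenyl)ethyl, a larger group than benzyl with a defined stereocentre, is accommodated: the step of a 1.9-fold lower number from compound 2 to compound 3 (0.27 log units; within the scatter) does not separate it from benzyl. Set against phenylsulfonyl, the same group gives a 4.0-fold lower number from compound 1 to compound 3 (0.60 log units; beyond the scatter) and so extends the earlier preference for a carbon substituent over the sulfonyl to a second, substituted example. No evidence on hand accounts for either step.

Open, on these data alone, is the opposite configuration at the stereocentre. Also open, as far as these compounds go, is how a carboxylic acid on the aromatic ring, in place of the acetamido group, would read.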